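Piperidin-3-yl in Place of Its Methylated Form

The compounds below may be only part of what the source reports. "The series", "measured", "known", "first", "only" and "open" are said of these compounds alone.

Compound 1 `Cc1ccc2[nH]c(C(=O)N[C@H]3CN(S(=O)(=O)c4ccccc4)C[C@@H]3C(=O)NC[C@H]3CCCN3C)cc2c1`: 98%
Compound 2 `Cc1ccc2[nH]c(C(=O)N[C@H]3CN(S(=O)(=O)c4ccccc4)C[C@@H]3C(=O)N[C@H]3CCCN(C)C3)cc2c1`: 99%

Both numbers come from a functional assay on HEK293 cells for agonist activity at growth hormone secretagogue receptor type 1 (Homo sapiens), read by HTRF and inositol phosphate accumulation, with a stated time of 90 min, in the presence of a further agent that is not named here; on this read-out lower numbers stand for smaller maximal responses and higher numbers for larger maximal responses. Of these two numbers compound 2 stands highest, with compound 1 nearest; the gap a number 1 percentage points higher from compound 1 to compound 2 (within the scatter) lies within the scatter.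

Compound 3 `Cc1ccc2[nH]c(C(=O)N[C@H]3CN(S(=O)(=O)c4ccccc4)C[C@@H]3C(=O)N[C@@H]3CCCNC3)cc2c1` carries the change (piperidin-3-yl in place of 1-methylpiperidin-3-yl on an amide-type nitrogen). Among the compounds with values here, the only measured step, a number 1 percentage points higher from compound 1 to compound 2 (within the scatter), also swapped the group on this amide-type nitrogen and left the response unchanged within the scatter. Within the data shown here, no measured step removes the methyl from a ring nitrogen, so the expectation rests on that single step alone: no movement beyond the scatter. Compound 3 is therefore expected to give 95%, within a range of 82% to 104%. This estimate means a step of a number 4 percentage points lower from compound 2 to compound 3 (within the scatter) is expected.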

Compound 3, largest response reached (Emax), in percent of the reference or control that the assay uses: 91%
Estimate against measurement, compound 3: 4 percentage points above; measured number inside the range.
By their numbers in this assay, from the lowest: compounds 3, 1 and 2 (each within the scatter of the next).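

Taking the methyl off the ring nitrogen gives a number 8 percentage points lower from compound 2 to compound 3 (within the scatter) in this assay, so a ring nitrogen with or without a methyl can sit on this amide-type nitrogen without a clear loss of maximal response. Against the (1-methylpyrrolidin-2-yl)methyl group, the result is a number 7 percentage points lower from compound 1 to compound 3 (within the scatter), so all three groups remain indistinguishable on this read-out. No measurement shown explains this tolerance.

Still open, going by these compounds, is whether the ring nitrogen is needed at all, which a plain cyclohexyl group on this amide-type nitrogen would test. A longer chain ending in a primary amine is equally untested among the compounds shown.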